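A few compounds are considered here, and "the series" means these few. Any claim that something is new, unique, unknown or untested is made for them only; others in the source may bear on it.

Measured in a functional assay on U-373MG ATCC cells (Homo sapiens) for inhibition, read by MTT assay, with a stated time of 72 h; on this read-out lower numbers stand for stronger inhibition of growth and higher numbers for weaker inhibition of growth:
- Compound 1 `CCOC(=O)/C=C/C1=CC[C@H]2C(C)(C)CCC[C@]2(C)[C@H]1C=O`: 37000 nM
- Compound 2 `CC1(C)CCC[C@]2(C)[C@@H](C=O)C(/C=C/C(=O)OCc3ccccc3)=CC[C@@H]12`: 39000 nM
- Compound 3 `CC(=O)/C=C/C1=CC[C@H]2C(C)(C)CCC[C@]2(C)[C@H]1C=O`: 25000 nM

Compound 3 stands level with the other two measured compounds, since neither of its steps leaves the scatter: a 1.5-fold lower number from compound 1 to compound 3 (0.17 log units; within the scatter), and a 1.6-fold lower number from compound 2 to compound 3 (0.19 log units; within the scatter). Those two steps are also the closest guide to compound 4 `C#CCCCOC(=O)/C=C/C1=CC[C@H]2C(C)(C)CCC[C@]2(C)[C@H]1C=O`, which differs from compound 3 by (pent-4-yn-1-yl)oxy in place of methyl on a carbonyl carbon.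

Read in reverse, both steps resemble this change, as each exchanges methyl on that carbonyl carbon with a group attached through oxygen, ethoxy in compound 1 and benzyloxy in compound 2. The exchange of one such group for the other also made little difference: a 1.1-fold higher number from compound 1 to compound 2 (0.02 log units; within the scatter). Going by the values given here, no measured compound carries a triple bond, so that feature remains untested in this assay.

On this evidence, no step beyond the scatter is expected, and any expected drift would be toward the values of compound 1 and compound 2. The expected step is a 1.4-fold higher number from compound 3 to compound 4 (0.15 log units; within the scatter). For compound 4 the estimated value is 35000 nM, with an expected range from 18000 nM to 70000 nM.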

Compound 4, concentration for 50% growth inhibition: 35000 nM
The estimate for compound 4 equals the measured number at the digits printed; the measured number falls inside the stated range.
By their numbers in this assay, from the lowest: compounds 3, 4, 1 and 2 (each within the scatter of the next).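

In this assay, going by these compounds alone, the place on a carbonyl carbon whose other neighbour is a double-bonded chain carbon now carries (pent-4-yn-1-yl)oxy, the first group with a triple bond, and the number stays level with that of the methyl group (a step of a 1.4-fold higher number from compound 3 to compound 4 (0.15 log units; within the scatter)). Compound 4 also stands level with the two shorter-named oxygen-linked groups, ethoxy (a step of a 1.1-fold lower number from compound 1 to compound 4 (0.02 log units; within the scatter)) and benzyloxy (a step of a 1.1-fold lower number from compound 2 to compound 4 (0.05 log units; within the scatter)), so a terminal triple bond on a longer chain brings no separation from either, and all four compounds remain within the scatter of one another at this position. Nothing measured here offers an account of why these different groups read alike.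

The compounds shown leave open whether any group on this carbonyl carbon can move the number beyond the scatter, for instance a carboxylic acid, an amide bearing a basic amine, or a much longer chain. They also leave open what a change elsewhere would do, since the shared core stays the same throughout.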